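Hydrazone series on a shared core: aryl substitution step

A few compounds are considered here, and "the series" means these few. Any claim that something is new, unique, unknown or untested is made for them only; others in the source may bear on it.

Compound 1 `CC1CCCc2ncc(C(=O)O)c(=O)n21` is the unsubstituted parent of the series; in a functional assay on the whole organism for inhibition, with Rattus norvegicus as the target (on this read-out higher numbers stand for an effect only at larger amounts of compound and lower numbers for an effect already at smaller amounts), compound 1 gives 240 umol/kg. Compound 2 `CC1CCC(=NNc2ccccc2)c2ncc(C(=O)O)c(=O)n21` carries a phenylhydrazone on the shared core, and in this assay compound 2 gives 0.6 umol/kg. Compound 3 `CC1CC/C(=N\Nc2ccccc2F)c2ncc(C(=O)O)c(=O)n21` carries the 2-fluorophenyl variant; in this assay compound 3 gives 5 umol/kg, the second highest of the three numbers, with compound 2 as its nearest neighbour and compound 1 furthest away, both gaps beyond the scatter.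

Compound 4 `CC1CC/C(=N\Nc2ccc(Br)cc2)c2ncc(C(=O)O)c(=O)n21` is not yet measured. Its difference from compound 3: 4-bromophenyl in place of 2-fluorophenyl on an amine nitrogen.

For the measured compounds named here, no measured pair shows this change directly. Compound 2 gives 0.6 umol/kg and compound 3 gives 5 umol/kg, so the aryl substituent on the amine nitrogen moves the read-out by a step beyond the scatter; the expected step of a 2.5-fold lower number from compound 3 to compound 4 (0.40 log units; beyond the scatter) is a moderate move toward a lower number. Compound 4 is estimated at 2 umol/kg, with a range from 0.5 umol/kg to 8 umol/kg.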

Compound 4, dose for 50% inhibition: 0.8 umol/kg
Compound 4: the middle estimate sits 2.5-fold (0.40 log units) above what was measured; the range from low to high includes it.
By their numbers in this assay, from the lowest: compounds 2 and 4 (each within the scatter of the next); then compound 3; then compound 1.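

Exchanging 2-fluorophenyl for 4-bromophenyl on the amine nitrogen gives a 6.3-fold lower number from compound 3 to compound 4 (0.80 log units; beyond the scatter) in this assay, so the read-out at this position depends on which substituted aryl group is present, not merely on whether the aryl group carries a halogen. Compound 2 at 0.6 umol/kg and compound 4 at 0.8 umol/kg lie within the scatter of each other, which leaves 2-fluorophenyl as the only aryl group shown here with a value set apart from the unsubstituted phenyl. No supporting data bear on the reason for this step.

The change swaps both the halogen and its location on the ring, so the two contributions cannot be separated; 4-fluorophenyl and 2-bromophenyl would separate them. On these data alone, whether a non-halogen substituent, such as methoxy or nitrile, fits this position also remains open.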